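Nitro in Place of Ethoxy on the Shared Core

A few compounds are considered here, and "the series" means these few. Any claim that something is new, unique, unknown or untested is made for them only; others in the source may bear on it.

In an ADME assay on HUVEC cells (Homo sapiens) for antiproliferative activity, read by MTT assay, with a stated time of 48 h (a lower number here means a stronger inhibitor, a higher number a weaker inhibitor), compound 2 `CCOc1ccc(-n2nncc2CN2C(=O)C3(C(C#N)=C(N)Oc4c3c3nc5ccccc5nc3c3ccccc43)c3ccccc32)cc1` gives only a limit, > 50000 nM. Compound 1 `N#CC1=C(N)Oc2c(c3nc4ccccc4nc3c3ccccc23)C12C(=O)N(Cc1cnnn1-c1cccc(Br)c1)c1ccccc12` likewise gives only a limit, > 50000 nM. The step that the two limits leave unreadable from compound 1 to compound 2 cannot be read because of the limit of > 50000 nM in this assay, at which 2 of the 2 values shown sit. Compound 3 `N#CC1=C(N)Oc2c(c3nc4ccccc4nc3c3ccccc23)C12C(=O)N(Cc1cnnn1-c1ccc([N+](=O)[O-])cc1)c1ccccc12` differs from compound 2 by nitro in place of ethoxy on an aromatic carbon. Going by the values given here, no measured step speaks to this change, the single step available being unreadable. Compound 3 is therefore expected to stay near the limit, with the step that the limit leaves unreadable from compound 2 to compound 3 expected to be no larger than the scatter. For compound 3 the estimate is 60000 nM, between 20000 nM and 200000 nM.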

Compound 3, half-maximal inhibitory concentration: > 50000 nM
Compound 3: a limit, no number; the forecaster's own chance of this, stated with the estimate: 80%; the middle value is on the limit's open side.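

No step among compound 1, compound 2 and compound 3 can be read, because all three stand at the same limit: the limit of > 50000 nM in this assay, at which 3 of the 3 values shown sit.

Going by these compounds, whether 3-bromophenyl, 4-ethoxyphenyl or 4-nitrophenyl makes any difference in this assay stays open.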